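The source may report more compounds than this note shows. Statements on the series, on what has been measured and on what is new or still open speak of the compounds shown alone.

Compound 1, `CC[C@@H](NC(=O)CC(C)C)C(=O)N1CCC(c2ccc(Cl)cc2)CC1`, is the weakest of the three compounds measured in an assay on THP-1 cells for displacement of a labelled ligand from C-C chemokine receptor type 1 (Homo sapiens) (a higher number here means a weaker inhibitor, a lower number a stronger inhibitor), where compound 1 gives 152 nM. Compound 3, `CC(C)CC(=O)N[C@@H](C(=O)N1CCC(c2ccc(Cl)cc2)CC1)C(C)C`, gives 32 nM in this assay, and compound 2, `Cc1ccc(C(=O)N[C@@H](C(=O)N2CCC(c3ccc(Cl)cc3)CC2)C(C)C)cc1`, gives 25 nM; the two lie within the scatter of each other. The step of a 4.8-fold lower number from compound 1 to compound 3 (0.68 log units; beyond the scatter) sets compound 1 apart from both.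

Compound 4, `CC[C@@H](NC(=O)CCc1ccccc1)C(=O)N1CCC(c2ccc(Cl)cc2)CC1`, differs from compound 1 in the acyl group on the amide: benzyl in place of isopropyl on a saturated chain carbon bound to a carbonyl carbon. Within the data shown here, only one of the measured steps touches this part of the molecule. From compound 2 to compound 3 the acyl carbonyl carries isobutyl in place of 4-methylphenyl, and the result is a 1.3-fold higher number from compound 2 to compound 3 (0.11 log units; within the scatter), so a switch between a branched chain and an aromatic acyl group at this position left the number unchanged within the scatter. The step of a 4.8-fold lower number from compound 1 to compound 3 (0.68 log units; beyond the scatter) concerns the other side chain and does not bear on the acyl group.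

On that basis compound 4 is expected to show a 1.3-fold lower number from compound 1 to compound 4 (0.10 log units; within the scatter), a step that stays within the scatter. The estimate for compound 4 in this assay is therefore 120 nM, with a range from 50 nM to 350 nM.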

Compound 4, half-maximal inhibitory concentration: 85 nM
Compound 4: middle estimate off by 1.4-fold (0.15 log units), on the high side; measured number inside the range.
By their numbers in this assay, from the lowest: compounds 2 and 3 (each within the scatter of the next); then compounds 4 and 1 (each within the scatter of the next).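

The step of a 1.8-fold lower number from compound 1 to compound 4 (0.25 log units; within the scatter) shows that in this assay the acyl side of compound 1 accepts benzyl in place of isopropyl, so 7 heavy atoms and one six-membered aromatic ring of carbon only enter where 3 carbon atoms and no ring leave, and the step stays within the scatter. Among these compounds, until now, the only reading at this part of the molecule was the swap between isobutyl and 4-methylphenyl on a carbonyl carbon in compounds 2 and 3; the new pair extends that reading to the other side chain, that of compound 1, and to an aromatic ring carried on a chain, since the same difference reads isobutyl to phenethyl. Nothing available here gives a reason for this result.

On these data alone, it remains open whether the phenethyl group would give a similar step on the side chain of compound 3, where the numbers are lower than for compound 1. As far as these compounds go, it is also open how this position would respond to a longer chain, or to an amine or a carboxylic acid on the chain or the phenyl ring.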